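This account rests on a few compounds, and the source may have more. Where it says the series, first, only, none or still open, it means among the compounds named here.

Three compounds have been measured in a functional assay on MKN-45 cells (Homo sapiens) for cytotoxicity, read by MTT assay, with a stated time of 72 h; on this read-out lower numbers stand for stronger inhibition and higher numbers for weaker inhibition:

Compound 1 `COc1cc2c(Oc3ccc(NC(=O)N/N=C/c4ccc(C(F)(F)F)cc4)cc3F)ccnc2cc1OCCCN1CCCC1` gives 1300 nM.
Compound 2 `COc1ccc(/C=N/NC(=O)Nc2ccc(Oc3ccnc4cc(OCCCN5CCC(C)CC5)c(OC)cc34)c(F)c2)cc1` gives 470 nM.
Compound 3 `COc1cc2c(Oc3ccc(NC(=O)N/N=C/c4ccc([N+](=O)[O-])cc4)cc3F)ccnc2cc1OCCCN1CCC(C)CC1` gives 420 nM.

Compound 3 holds the lowest number of the three. Compound 2 sits within the scatter of it, so the two cannot be told apart, while compound 1 lies beyond the scatter. Going by the values given here, the only single-point change measured so far, a 1.1-fold lower number from compound 2 to compound 3 (0.05 log units; within the scatter), exchanges methoxy for nitro on the ring at the far end of the molecule and leaves the read-out essentially unchanged.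

Compound 4 `COc1cc2c(Oc3ccc(NC(=O)N/N=C/c4ccc(C(F)(F)F)cc4)cc3F)ccnc2cc1OCCCN1CCC(C)CC1` is the next candidate. It differs from compound 3 in one place: trifluoromethyl in place of nitro on an aromatic carbon. Among the compounds with values here, no measured step compares trifluoromethyl with nitro directly. Compound 1 carries the same trifluoromethyl group but also a different amine ring, so its value is only a rough hint that such an analogue may sit toward the weaker end. On that basis compound 4 is expected to give 800 nM, within a range from 300 nM to 2500 nM. The expected step is therefore a 1.9-fold higher number from compound 3 to compound 4 (0.28 log units; within the scatter), a modest move toward weaker inhibition, chiefly because compound 1 gives 1300 nM.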

Compound 4, half-maximal inhibitory concentration: 1000 nM
Compound 4: the middle estimate sits 1.3-fold (0.10 log units) below what was measured, within the range that was stated.
By their numbers in this assay, from the lowest: compounds 3 and 2 (each within the scatter of the next); then compounds 4 and 1 (each within the scatter of the next).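

In this assay the position on the aromatic ring para to a large group now shows that the choice of group there can matter, where the swap of methoxy for nitro had shown nothing beyond the scatter: the change from nitro to trifluoromethyl gives a 2.4-fold higher number from compound 3 to compound 4 (0.38 log units; beyond the scatter) and the change from methoxy to trifluoromethyl gives a 2.1-fold higher number from compound 2 to compound 4 (0.33 log units; beyond the scatter) as the two modest shifts seen so far. At the other end of the molecule, with trifluoromethyl kept in place, putting 4-methylpiperidin-1-yl where pyrrolidin-1-yl stood gives a 1.3-fold lower number from compound 1 to compound 4 (0.11 log units; within the scatter) and so leaves the two compounds indistinguishable in this pair. Nothing available here explains why trifluoromethyl behaves differently from nitro and methoxy at this position.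

Going by these compounds, whether a chlorine atom, a nitrile or an amine at this position would group with nitro and methoxy or with trifluoromethyl remains open. On these data alone, the comparison of amine rings rests on a single pair, so it is also open whether morpholine at the end of the chain, or pyrrolidin-1-yl combined with nitro, would give a similar result.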